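From Pyridin-3-yl to Pyridin-4-yl on a Shared Core

The source may report more compounds than this note shows. Statements on the series, on what has been measured and on what is new or still open speak of the compounds shown alone.

In a physicochemical assay for lipophilicity, at pH 7.4 (on this read-out lower numbers stand for lower lipophilicity and higher numbers for higher lipophilicity), compound 1 `CNC(=O)c1cc(C(=O)NC2CCC2)cn(Cc2ccccn2)c1=O` gives 2.2. Going by the values given here, compound 2 `CNC(=O)c1cc(C(=O)NC2CCC2)cn(Cc2cccnc2)c1=O` gives 1.8, the lower of the two numbers measured so far. Compound 3 `CNC(=O)c1cc(C(=O)NC2CCC2)cn(Cc2ccncc2)c1=O` has not yet been measured. Its structure departs from that of compound 2 by one change, (pyridin-4-yl in place of pyridin-3-yl on a saturated chain carbon bound to an aromatic nitrogen), with pyridin-4-yl in place of pyridin-3-yl on a saturated chain carbon bound to an aromatic nitrogen. The two have the same atoms, joined differently. Among the compounds with values here, only one measured step bears on this, a modest one beyond the scatter at the same place, a number 0.40 log units lower from compound 1 to compound 2 (beyond the scatter). Within the data shown here, it shows that such a change can register, but no pyridin-4-yl compound has been measured to set a direction. The expected step is therefore none beyond the scatter, no change at the digits printed from compound 2 to compound 3 (within the scatter). In this assay the estimate for compound 3 is 1.8, with an expected range of 1.5 to 2.1.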

Compound 3, distribution coefficient: 1.7
Estimate against measurement, compound 3: 0.10 log units above; measured number inside the range.
By their numbers in this assay, from the lowest: compounds 3 and 2 (each within the scatter of the next); then compound 1.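

In this assay, pyridin-4-yl in place of pyridin-3-yl on a saturated chain carbon bound to an aromatic nitrogen gives a number 0.10 log units lower from compound 2 to compound 3 (within the scatter), so these two groups cannot be told apart at this position. Pyridin-4-yl in place of pyridin-2-yl at the same place gives a number 0.50 log units lower from compound 1 to compound 3 (beyond the scatter), which leaves compound 1 beyond the scatter from both other compounds and makes pyridin-2-yl the only one of the three groups that separates on this read-out. Nothing on hand accounts for why compound 1 stands apart from the other two.

Open, on these data alone, is whether a phenyl group at this place would fall with compound 1 or with the other two compounds. Also open, as far as these compounds go, is whether a longer chain carrying pyridin-4-yl would stay within the scatter of compound 3.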